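Swapping ethyl for 4-methoxyphenyl: what to expect

The compounds below may be only part of what the source reports. "The series", "measured", "known", "first", "only" and "open" are said of these compounds alone.

- compound 1 `CNC(=S)N/N=C/c1cccc2ccccc12`: 2000 nM
- compound 2 `CCNC(=S)N/N=C/c1cccc2ccccc12`: 1100 nM
- compound 3 `Cc1ccc(NC(=S)N/N=C/c2cccc3ccccc23)cc1`: 580 nM

These values come from a functional assay on B16 cells (Mus musculus), read by spectrophotometry, with a stated time of 3 days; on this read-out lower numbers stand for stronger inhibition and higher numbers for weaker inhibition. Compound 2 gives 1100 nM, which lies within the scatter of both other measured compounds: there is a 1.8-fold lower number from compound 1 to compound 2 (0.26 log units; within the scatter) and a 1.9-fold lower number from compound 2 to compound 3 (0.28 log units; within the scatter).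

Compound 4 `COc1ccc(NC(=S)N/N=C/c2cccc3ccccc23)cc1` has not yet been measured. The change is 4-methoxyphenyl in place of ethyl on an amide-type nitrogen.

The nearest guide is compound 3, which carries 4-methylphenyl in place of ethyl on that nitrogen, with a 1.9-fold lower number from compound 2 to compound 3 (0.28 log units; within the scatter). The swap from methyl to 4-methylphenyl is larger but still modest, at a 3.4-fold lower number from compound 1 to compound 3 (0.54 log units; beyond the scatter). Going by the values given here, no measured compound carries 4-methoxyphenyl, so the range stays wide. A small move to a lower number is therefore expected in this assay, possibly no larger than the scatter. The estimated step is a 1.8-fold lower number from compound 2 to compound 4 (0.26 log units; within the scatter). For compound 4 the expected value is 600 nM, with an estimated range of 270 nM to 1300 nM.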

Compound 4, half-maximal inhibitory concentration: 860 nM
Beside the measured number, compound 4's estimate is 1.4-fold (0.16 log units) below it; measured number inside the range.
By their numbers in this assay, from the lowest: compounds 3, 4, 2 and 1 (each within the scatter of the next, the first and the last beyond it).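

In this assay the 4-methoxyphenyl group gives a second example of a substituted phenyl ring on this amide-type nitrogen, and it cannot be told apart from ethyl (a 1.3-fold lower number from compound 2 to compound 4 (0.11 log units; within the scatter)) or from the 4-methylphenyl group, where methoxy replaces methyl on an aromatic carbon (a 1.5-fold higher number from compound 3 to compound 4 (0.17 log units; within the scatter)). Only against the methyl group of compound 1 does it give a step beyond the scatter (a 2.3-fold lower number from compound 1 to compound 4 (0.37 log units; beyond the scatter)), as the 4-methylphenyl group also does (a 3.4-fold lower number from compound 1 to compound 3 (0.54 log units; beyond the scatter)), so compound 3 and compound 4 both differ clearly from compound 1 but not from compound 2. Nothing available explains why these steps are so small.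

A plain phenyl ring would show whether the methyl and methoxy groups matter at all. A longer chain such as butyl would show whether a ring is needed on this nitrogen.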